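From the amino chain of compound 3 to hydroxymethyl

A few compounds are considered here, and "the series" means these few. Any claim that something is new, unique, unknown or untested is made for them only; others in the source may bear on it.

In a functional assay on SW-620 cells (Homo sapiens) for inhibition, read by MTT assay, with a stated time of 72 h (a higher number here means a weaker inhibitor, a lower number a stronger inhibitor), compound 1 `COc1cc(Oc2cccc(Nc3ccccc3)c2)cc(OC)c1CNCc1ccc(F)cc1` gives 6770 nM, compound 2 `COc1cc(Oc2cccc(Nc3ccccc3)c2)cc(OC)c1CNCc1ccc(Cl)cc1` gives 6340 nM and compound 3 `COc1ccc(CCCNCc2c(OC)cc(Oc3cccc(Nc4ccccc4)c3)cc2OC)cc1` gives 6400 nM. Compound 3 therefore stands level with the other two within the scatter, with no order among the three.

Compound 4 `COc1cc(Oc2cccc(Nc3ccccc3)c2)cc(OC)c1CCO` differs from compound 3 as follows: hydroxymethyl in place of (3-(4-methoxyphenyl)propyl)amino on a saturated chain carbon bound to an aromatic carbon. This places hydroxymethyl in place of (3-(4-methoxyphenyl)propyl)amino on a saturated chain carbon bound to an aromatic carbon.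

Three measured steps offer some guidance. Changing the halogen gives a 1.1-fold lower number from compound 1 to compound 2 (0.03 log units; within the scatter). Changing the group on the amine gives a 1.1-fold lower number from compound 1 to compound 3 (0.02 log units; within the scatter) and a 1.0-fold higher number from compound 2 to compound 3 (0.00 log units; within the scatter). All three lie within the scatter, so the amine substituents tried so far leave this assay flat. For the measured compounds named here, none of these steps removes the amino group itself, and no measured compound lacks it, so the data do not settle the outcome of this change. A moderate move to a higher number is expected, with little confidence in its direction or size, and a result within the scatter remains possible.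

The expected step is a 1.9-fold higher number from compound 3 to compound 4 (0.27 log units; within the scatter). For compound 4 the estimated value is 12000 nM, with an expected range of 4500 nM to 35000 nM.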

Compound 4, half-maximal inhibitory concentration: > 20000 nM
Compound 4: a limit, no number (the forecaster's own chance of this, stated with the estimate: 25%); middle value at least 1.6-fold (0.22 log units) away from the limit.
By their numbers in this assay, from the lowest: compounds 2, 3 and 1 (each within the scatter of the next). At a limit, above all of these: compound 4.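

The reading for compound 4 in this assay is a limit of the assay and not a number: the limit of > 20000 nM in this assay, at which 1 of the 4 values shown sits.

Read against each of the amine compounds, replacing the amino chain with hydroxymethyl gives a step beyond the scatter: an at least 3.1-fold higher number from compound 3 to compound 4 (0.49 log units; beyond the scatter), an at least 3.1-fold higher number from compound 2 to compound 4 (0.49 log units; beyond the scatter) and an at least 2.9-fold higher number from compound 1 to compound 4 (0.47 log units; beyond the scatter). The saturated chain carbon bound to an aromatic carbon is thus no longer a flat position: (4-fluorobenzyl)amino, (4-chlorobenzyl)amino and (3-(4-methoxyphenyl)propyl)amino stand within the scatter of each other, whereas hydroxymethyl in their place separates from all three in the direction of a weaker inhibitor.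

The change removes the amine nitrogen and the aromatic ring of the chain together, so the compounds shown do not assign the step to either part; methylamino would keep the nitrogen without that ring, and benzyloxy would keep a ring without the nitrogen. From the compounds shown here alone, the full size of the step also remains open, since a limit gives compound 4 no number to set against the others.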